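This account rests on a few compounds, and the source may have more. Where it says the series, first, only, none or still open, it means among the compounds named here.

Measured compounds:
- compound 1, `O=C(Nc1cccc(-c2oc3cc(-c4ccc(F)cc4)ccc3c(=O)c2O)c1)c1ccccc1F`: 10800 nM
- compound 2, `O=C(Nc1cccc(-c2oc3cc(-c4ccc(F)cc4)ccc3c(=O)c2O)c1)c1ccc(Cl)cc1`: 4030 nM
- compound 3, `CCc1ccc(C(=O)Nc2cccc(-c3oc4cc(-c5ccc(F)cc5)ccc4c(=O)c3O)c2)cc1`: 13200 nM

These three share one core and differ only in the aromatic group attached to the carbonyl carbon of the amide. In a functional assay on HCC1937 cells (Homo sapiens) for antiproliferative activity, read by CCK-8 assay, with a stated time of 72 h (on this read-out higher numbers stand for weaker inhibition and lower numbers for stronger inhibition), compound 1 gives 10800 nM, the second highest of the three numbers; compound 3 sits nearest, and the two lie within the scatter of each other, while compound 2 is furthest, with the step of a 2.7-fold lower number from compound 1 to compound 2 (0.43 log units; beyond the scatter).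

Compound 4, `O=C(Nc1cccc(-c2oc3cc(-c4ccc(F)cc4)ccc3c(=O)c2O)c1)c1ccc(Cl)nc1`, has not yet been measured. It differs from compound 1 in one place: 6-chloropyridin-3-yl in place of 2-fluorophenyl on a carbonyl carbon.

Among the compounds with values here, of the measured steps, only one bears on this change directly. Moving a chloro group into the ring at the position seen in compound 2 gave a 2.7-fold lower number from compound 1 to compound 2 (0.43 log units; beyond the scatter), a modest step beyond the scatter. Within the data shown here, no measured pair shows what replacing a ring carbon with a ring nitrogen does, so that part of the change is an open question. Compound 3 shows that not every group in this place lowers the number: a 1.2-fold higher number from compound 1 to compound 3 (0.09 log units; within the scatter).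

On balance a modest step toward a lower number is expected, of about a 2.0-fold lower number from compound 1 to compound 4 (0.29 log units; within the scatter). Compound 4 is therefore estimated at 5500 nM, with a range from 2000 nM to 15000 nM.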

Compound 4, half-maximal inhibitory concentration: 7550 nM
Compound 4: middle estimate off by 1.4-fold (0.14 log units), on the low side, and the stated range covers the measured number.
By their numbers in this assay, from the lowest: compounds 2, 4, 1 and 3 (each within the scatter of the next, the first and the last beyond it).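

In this assay, compound 4 brings the first ring nitrogen at this place, and the closest comparison is a 1.9-fold higher number from compound 2 to compound 4 (0.27 log units; within the scatter), where the chloro group stays and a ring carbon gives way to that nitrogen; this step lies within the scatter, so the ring nitrogen produces no clear shift in this pair. The two other steps, a 1.4-fold lower number from compound 1 to compound 4 (0.16 log units; within the scatter) and a 1.7-fold lower number from compound 3 to compound 4 (0.24 log units; within the scatter), also lie within the scatter, which leaves compound 4 not clearly separated from any of the three earlier compounds, even though compound 2 stands beyond the scatter from both compound 1 and compound 3. No measurement shown here offers an explanation for this result.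

Going by these compounds, all four groups at this place are six-membered aromatic rings, so it remains open how a saturated ring such as piperidine, or a ring carrying an amine or a carboxylic acid, would behave here. The ring nitrogen has also been seen only alongside a chloro group, so a plain pyridin-3-yl or a 6-methylpyridin-3-yl group would be needed to show whether the same holds without it.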